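Swapping the phenyl substituent on a triazole-linked sulfonamide

The source may report more compounds than this note shows. Statements on the series, on what has been measured and on what is new or still open speak of the compounds shown alone.

Measured compounds:
compound 1 `O=c1[nH]cc(S(=O)(=O)Nc2cccc(-c3cn(-c4ccccc4)nn3)c2)c(=O)[nH]1`: 22500 nM
compound 2 `Cc1ccc(-n2cc(-c3cccc(NS(=O)(=O)c4c[nH]c(=O)[nH]c4=O)c3)nn2)cc1`: 15800 nM

In an ADME assay on GES1 cells (Homo sapiens) for cytotoxicity, read by MTT assay, with a stated time of 24 h (on this read-out lower numbers stand for higher toxicity in this test and higher numbers for lower toxicity in this test), compound 2 gives 15800 nM and compound 1 gives 22500 nM; the two values lie within the scatter of each other, so neither can be set apart. Within the data shown here, the only measured step, a 1.4-fold lower number from compound 1 to compound 2 (0.15 log units; within the scatter), is a methyl in place of hydrogen on an aromatic carbon and stays within the scatter. Compound 3 `O=c1[nH]cc(S(=O)(=O)Nc2cccc(-c3cn(-c4ccccc4Cl)nn3)c2)c(=O)[nH]1` differs from compound 2 by 2-chlorophenyl in place of 4-methylphenyl on an aromatic nitrogen. Among the measured compounds shown here, no measured step covers a chlorine on that ring, and the one step at hand was small, so no change beyond the scatter is expected: a 1.1-fold higher number from compound 2 to compound 3 (0.06 log units; within the scatter). Compound 3 is therefore estimated at 18000 nM, within 8000 nM to 40000 nM.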

Compound 3, half-maximal cytotoxic concentration: 14000 nM
Compound 3: middle estimate off by 1.3-fold (0.11 log units), on the high side; the range from low to high includes it.
By their numbers in this assay, from the lowest: compounds 3, 2 and 1 (each within the scatter of the next).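

In this assay, 2-chlorophenyl in place of 4-methylphenyl gives a 1.1-fold lower number from compound 2 to compound 3 (0.05 log units; within the scatter), and a chlorine added to the phenyl ring gives a 1.6-fold lower number from compound 1 to compound 3 (0.21 log units; within the scatter). This position on an aromatic nitrogen has now carried three different phenyl groups with no value set apart, so a chlorine, like the methyl before it, shifts the number only within the scatter. No evidence on the cause is available. Still open, from the compounds shown here alone, is whether a carboxylic acid or an amine on that phenyl ring, or a longer chain in place of the ring, would move the number beyond the scatter.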